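The compounds below may be only part of what the source reports. "The series", "measured", "known", "first", "only" and "open" are said of these compounds alone.

Measured compounds in a functional assay on MCF7 cells (Homo sapiens) for cytotoxicity, read by MTT assay, with a stated time of 2 days, tested at 100 uM; on this read-out lower numbers stand for a stronger effect and higher numbers for a weaker effect at the one concentration tested:
Compound 1 `COc1ccc(-c2cc(C(C)=O)c3[nH]c(-c4ccccc4)cc3c2)cc1` gives 30.8%.
Compound 2 `COc1ccc(-c2cc(C(C)=O)c3[nH]c(-c4ccc(OC)cc4)cc3c2)cc1` gives 39.9%.

Among the measured compounds shown here, compound 2 and compound 1 lie within the scatter of each other, the only step being a number 9.1 percentage points higher from compound 1 to compound 2 (within the scatter). Compound 3 `COc1ccc(-c2cc3cc(/C=C/c4ccc(F)cc4)cc(C(C)=O)c3[nH]2)cc1` has not yet been measured; it differs from compound 2 in one place: 2-(4-fluorophenyl)ethenyl in place of 4-methoxyphenyl on an aromatic carbon. No measured step exchanges one aryl group for another, so nothing among the shown numbers bears directly on this change, and the expectation for this assay is a step of about a number 1.9 percentage points lower from compound 2 to compound 3 (within the scatter), not beyond the scatter. Compound 3 is therefore estimated at 38%, between 15% and 65%.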

Compound 3, a percentage reported as activity, at one concentration (the size of the read-out at that concentration, not a potency): 47.6%
Compound 3: middle estimate off by 9.6 percentage points, on the low side; the range from low to high includes it.
By their numbers in this assay, from the lowest: compounds 1, 2 and 3 (each within the scatter of the next, the first and the last beyond it).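

In this assay, 2-(4-fluorophenyl)ethenyl in place of 4-methoxyphenyl gives a number 7.7 percentage points higher from compound 2 to compound 3 (within the scatter). This position, meta to the acetyl group, therefore accepts a double bond outside the aromatic rings, with the aromatic ring carried on it, while the two compounds stay within the scatter of each other. Nothing available here explains this result. Still open, from the compounds shown here alone, is whether an amine or a carboxylic acid on the ring of this group would move the read-out beyond the scatter. Also open, going by these compounds, is how a saturated chain in place of the ethenyl link would read.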